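Aryl replacement on the shared core of compound 1

The source may hold more compounds than are shown below. What is called first, only, known or untested is meant among the compounds shown, and "the series" means these compounds.

Measured compounds:
- compound 1 `CC(=O)N1c2ccc(-c3ccc(S(C)(=O)=O)cc3)cc2N(C(=O)c2ccco2)C[C@@H]1C`: 400 nM
- compound 2 `COC(=O)N1c2ccc(-c3ccc(S(C)(=O)=O)cc3)cc2N(C(=O)c2ccco2)C[C@@H]1C`: 320 nM
- compound 3 `CC(=O)N1c2ccc(-c3ccc(S(C)(=O)=O)cc3)cc2N(C(=O)C2CC2)C[C@@H]1C`: 830 nM

In a functional assay on MV4-11 cells (Homo sapiens) for inhibition, read by luminescence and CellTiter-Glo, with a stated time of 72 h (on this read-out lower numbers stand for stronger inhibition of growth and higher numbers for weaker inhibition of growth), compound 1 gives 400 nM and stands second highest of the three numbers. Its nearest neighbour is compound 2, with a 1.3-fold lower number from compound 1 to compound 2 (0.10 log units; within the scatter); the furthest is compound 3, with a 2.1-fold higher number from compound 1 to compound 3 (0.32 log units; beyond the scatter). Both measured steps change a group on a carbonyl carbon and leave the aromatic substituent of the core untouched.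

Compound 4 `CC(=O)N1c2ccc(-c3cnn(C)c3)cc2N(C(=O)c2ccco2)C[C@@H]1C` differs from compound 1 in exactly that untouched position: 1-methyl-1H-pyrazol-4-yl in place of 4-(methylsulfonyl)phenyl on an aromatic carbon. Going by the values given here, no measured step bears on this change, so the two known steps give only a sense of scale, not direction. The shared core, the acetyl group and the furan-2-yl carbonyl are all retained. With nothing in the series to anchor the aryl swap, the expectation for compound 4 is kept near compound 1 with a wide margin: the estimated value in this assay is 650 nM, expected between 150 nM and 2800 nM, corresponding to an expected 1.6-fold higher number from compound 1 to compound 4 (0.21 log units; within the scatter).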

Compound 4, concentration for 50% growth inhibition: 210 nM
Beside the measured number, compound 4's estimate is 3.1-fold (0.49 log units) above it, and the stated range covers the measured number.
By their numbers in this assay, from the lowest: compounds 4, 2 and 1 (each within the scatter of the next); then compound 3.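

In this assay, the aromatic substituent of the shared core gives its first reading: a 1.9-fold lower number from compound 1 to compound 4 (0.28 log units; within the scatter). The position therefore accepts 1-methyl-1H-pyrazol-4-yl, with 6 heavy atoms and one five-membered aromatic ring, in place of 4-(methylsulfonyl)phenyl, with 10 heavy atoms and one six-membered aromatic ring, with the number staying within the scatter. No supporting data explain this outcome.

On these data alone, it remains open whether a pyridine ring, a morpholine or an unsubstituted phenyl at this aromatic carbon would stay in the same range. As far as these compounds go, it is also open whether the pyrazole step would hold with the methoxy or cyclopropyl groups on the carbonyl carbons, since each of these changes has been read only with 4-(methylsulfonyl)phenyl in place.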